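From difluorophenyl to furan in a cytotoxic series

This account rests on a few compounds, and the source may have more. Where it says the series, first, only, none or still open, it means among the compounds named here.

Measured in a functional assay on MCF7 cells (Homo sapiens) for cytotoxicity, read by MTT assay, with a stated time of 72 h; a lower number here means a stronger inhibitor, a higher number a weaker inhibitor:
Compound 1 `O=C1C(=Cc2ccc(Br)cc2)C(=O)N(c2ccc(Cl)cc2)N1c1ccc(Cl)cc1`: 30400 nM
Compound 2 `COc1ccc(C=C2C(=O)N(c3ccc(Cl)cc3)N(c3ccc(Cl)cc3)C2=O)cc1`: > 128000 nM (a limit of the assay)
Compound 3 `O=C1C(=Cc2ccc(F)cc2F)C(=O)N(c2ccc(Cl)cc2)N1c1ccc(Cl)cc1`: 22000 nM

Among the measured compounds shown here, compound 3, at 22000 nM, sits within the scatter of compound 1, and these are the only two true numbers so far. Compound 2 gives only a limit.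

Compound 4 `O=C1C(=Cc2ccco2)C(=O)N(c2ccc(Cl)cc2)N1c1ccc(Cl)cc1` carries furan-2-yl in place of 2,4-difluorophenyl on a double-bonded chain carbon bound to a double-bonded ring carbon. The measured steps all concern the group at this end of the molecule. One exchange of aromatic groups gave a 1.4-fold lower number from compound 1 to compound 3 (0.14 log units; within the scatter). By contrast, an at least 4.2-fold higher number from compound 1 to compound 2 (0.62 log units; beyond the scatter) and an at least 5.8-fold lower number from compound 2 to compound 3 (0.76 log units; beyond the scatter) show that a change here can go beyond the scatter. None of these compounds has a five-membered aromatic ring, so the guidance is loose.

The expected step is a 1.8-fold higher number from compound 3 to compound 4 (0.26 log units; within the scatter), which leans towards a higher number without a clear change beyond the scatter. For compound 4 the estimate is 40000 nM, with an expected range from 14000 nM to 120000 nM.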

Compound 4, half-maximal inhibitory concentration: 20300 nM
Compound 4: middle estimate off by 2.0-fold (0.29 log units), on the high side; low and high end bracket the measured number.
By their numbers in this assay, from the lowest: compounds 4, 3 and 1 (each within the scatter of the next). At a limit, above all of these: compound 2.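

In this assay, a five-membered aromatic ring with one hetero atom can take this place on the double-bonded chain carbon, since the steps are a 1.1-fold lower number from compound 3 to compound 4 (0.03 log units; within the scatter) and a 1.5-fold lower number from compound 1 to compound 4 (0.18 log units; within the scatter) and neither leaves the scatter. The earlier compounds shown here all carry six-membered aromatic rings here, whereas furan-2-yl has fewer heavy atoms and still sits level with 2,4-difluorophenyl and 4-bromophenyl. The comparison with 4-methoxyphenyl is open-ended, with an at least 6.3-fold lower number from compound 2 to compound 4 (0.79 log units; beyond the scatter) as the step and compound 2 given only as a limit: the limit of > 128000 nM in this assay, at which 1 of the 4 values shown sits.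

Furan-2-yl is the only five-membered ring shown, so it remains open whether a thiophene ring, or a phenyl ring carrying an amine or a carboxylic acid, would stay at this level. As far as these compounds go, the rest of the shared core is the same in all four compounds, and its part in these numbers also remains open.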